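This account rests on a few compounds, and the source may have more. Where it says the series, first, only, none or still open, it means among the compounds named here.

Measured so far:
compound 1, `O=C1O[C@H]([C@@H](O)Cn2cc(-c3ccc(Br)cc3)nn2)C(OCc2ccccc2)=C1OCc1ccccc1` — 5100 nM
compound 2, `O=C1O[C@H]([C@@H](O)Cn2cc(-c3cc(C(F)(F)F)cc(C(F)(F)F)c3)nn2)C(OCc2ccccc2)=C1OCc1ccccc1` — 80700 nM

In an ADME assay on HFF cells (Homo sapiens) for cytotoxicity, read by MTT assay, with a stated time of 72 h (on this read-out lower numbers stand for stronger inhibition and higher numbers for weaker inhibition), compound 1 gives the lower of the two numbers, and compound 2 gives the higher one; the gap between them lies beyond the usual scatter, so the pendant aryl group on the triazole clearly matters for this read-out. Among the measured compounds shown here, no single-point step between measured compounds is available.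

Compound 3, `O=C1O[C@H]([C@@H](O)Cn2cc(CNS(=O)(=O)c3ccc(Cl)cc3)nn2)C(OCc2ccccc2)=C1OCc1ccccc1`, is not yet measured. It differs from compound 1 by (((4-chlorophenyl)sulfonyl)amino)methyl in place of 4-bromophenyl on an aromatic carbon. The entering group brings a hydrogen-bond donor and two acceptors where compound 1 has none.

Compound 3 is expected to show a somewhat higher number than compound 1 in this assay, a step of a 3.9-fold higher number from compound 1 to compound 3 (0.59 log units; beyond the scatter), though the direction rests only on the spread seen between compound 1 and compound 2. The estimate for compound 3 is 20000 nM, within a range of 5000 nM to 80000 nM.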

Compound 3, half-maximal inhibitory concentration: 20 nM
The estimate for compound 3 lay 1000-fold (3.00 log units) above the measured number; measured number below the stated range.
By their numbers in this assay, from the lowest: compound 3; then compound 1; then compound 2.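

At the aromatic carbon of the five-membered aromatic ring with 3 nitrogen, the read-out in this assay shows a 260-fold lower number from compound 1 to compound 3 (2.41 log units; beyond the scatter) when (((4-chlorophenyl)sulfonyl)amino)methyl stands in place of 4-bromophenyl, so this position is far more sensitive than the aryl-bearing compounds alone could show. The change alters the link to the aromatic ring, the hydrogen-bond donor and acceptor counts and the halogen all at once, and the step cannot be divided among these parts. Nothing at hand accounts for the size of this step.

The compounds shown leave open whether the sulfonyl group itself is needed, which a carboxamide link or a simple aminomethyl group at this position would address. Also open, on these data alone, is whether chlorine on the phenyl ring contributes, as against bromine or hydrogen on the same sulfonyl chain.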